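The source may report more compounds than this note shows. Statements on the series, on what has been measured and on what is new or still open speak of the compounds shown alone.

Compound 1 `CCC(CC)(CC(=O)Nc1cccc(OCc2ccc3cccc(F)c3n2)c1)C(=O)O` gives 6 nM in a functional assay on ileum (Cavia porcellus) for antagonist activity at cysteinyl leukotriene receptor (Homo sapiens); on this read-out higher numbers stand for weaker inhibition and lower numbers for stronger inhibition.
Compound 2 `CCC(CC)(CC(=O)Nc1cccc(OCc2ccc3ccc(C(C)=O)cc3n2)c1)C(=O)O` gives 2500 nM in this assay.
Compound 3 `O=C(O)CCC(=O)Nc1cccc(OCc2ccc3ccc(F)cc3n2)c1` gives 200 nM in this assay.

Among these three measured compounds, compound 3 stands at the second highest number. Its nearest neighbour is compound 2, whose number is higher by a margin beyond the usual scatter, while compound 1 lies furthest away, at a lower number, again beyond the scatter. Compound 1 and compound 3 differ from each other in more than one place, so their values can only be set side by side, not read as a single step.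

Compound 4 `CC(C)(CC(=O)Nc1cccc(OCc2ccc3ccc(F)cc3n2)c1)C(=O)O` differs from compound 3 in one place: 1-carboxy-1-methylethyl in place of carboxymethyl on a saturated chain carbon bound to a carbonyl carbon. Within the data shown here, no measured pair shows this exact change, so the expectation rests on the values alone. Compound 1, which carries two ethyl groups on the chain carbon bound to the carbonyl carbon, shows a markedly lower number with 6 nM than compound 3 with 200 nM, and compound 4 takes a smaller step in that same direction. The step from compound 3 to compound 4 is therefore expected to be a 5.0-fold lower number from compound 3 to compound 4 (0.70 log units; beyond the scatter), toward a lower number and beyond the scatter. Compound 4 is estimated at 40 nM, within a range from 10 nM to 150 nM.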

Compound 4, half-maximal inhibitory concentration: 1.4 nM
Compound 4: middle estimate off by 29-fold (1.46 log units), on the high side; the whole stated range lies above it.
By their numbers in this assay, from the lowest: compound 4; then compound 1; then compound 3; then compound 2.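

In this assay, among these compounds, the change from carboxymethyl to 1-carboxy-1-methylethyl on a saturated chain carbon bound to a carbonyl carbon gives a 140-fold lower number from compound 3 to compound 4 (2.15 log units; beyond the scatter) and is the first step read with the rest of the structure held fixed. Among the compounds shown here, it shows that this one position, on its own, can shift the number by a large margin, whereas the earlier compounds differed in more than one place and could only be set side by side. No measurement among these compounds accounts for the size of this step.

As far as these compounds go, it remains open how a single methyl group or a cyclopropane ring at that chain carbon would read on the same core. Also open, from the compounds shown here alone, is whether a tetrazole in place of the carboxylic acid would keep the low number of compound 4 at 1.4 nM in this assay.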